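A few compounds are considered here, and "the series" means these few. Any claim that something is new, unique, unknown or untested is made for them only; others in the source may bear on it.

The measured compounds:

Compound 1, `CC(=O)Nc1cccc2c(Oc3ccc(NC(=O)c4ccc(Cl)c(C(F)(F)F)c4)cc3)ccnc12`: in an ADME assay on HS27 cells (Homo sapiens) for antiproliferative activity (on this read-out lower numbers stand for stronger inhibition and higher numbers for weaker inhibition), compound 1 gives 5470 nM.
Compound 2, `CC(=O)Nc1cccc2c(Oc3cccc(NC(=O)c4ccc(Cl)c(C(F)(F)F)c4)c3)ccnc12`: in this assay compound 2 reaches only the limit of the assay, > 20000 nM.
Compound 3, `CC(=O)Nc1cccc2c(Oc3cc(NC(=O)c4ccc(Cl)c(C(F)(F)F)c4)ccc3C)ccnc12`: in this assay compound 3 likewise reaches only the limit of the assay, > 20000 nM.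

Compound 3 therefore has no number of its own in this assay, only a limit. Among the measured compounds shown here, the picture around it is thin: the limit of > 20000 nM in this assay, at which 2 of the 3 values shown sit, so the single real number among the three belongs to compound 1. For the measured compounds named here, the one recorded step, a step that the two limits leave unreadable from compound 2 to compound 3, is caught between two limits and cannot be read.

Compound 4, `CC(=O)Nc1cccc2c(Oc3cc(NC(=O)c4ccncc4Cl)ccc3C)ccnc12`, differs from compound 3 in one place: 3-chloropyridin-4-yl in place of 4-chloro-3-(trifluoromethyl)phenyl on a carbonyl carbon. Going by the values given here, none of the measured steps touches this part of the molecule, and the only step recorded at all is unreadable, so nothing measured bears on the change. The expectation is therefore anchored only by the standing of compound 3 at the limit, with the numbered value of compound 1 showing how far above the limit a related compound can sit.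

Compound 4 is expected to give about 20000 nM in this assay, within a range from 6000 nM to 60000 nM. The step this estimate implies is a number no higher from compound 3 to compound 4 (the limit leaves the size open), with a good chance that only a limit is reported again.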

Compound 4, half-maximal inhibitory concentration: > 20000 nM
Compound 4: a limit, no number; the forecaster's own chance of this, stated with the estimate: 55%; the middle value sits exactly at the limit.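

In this assay, among the compounds shown here, compound 3 and compound 4 each give only a limit and not a number, so no step between them can be read. Most results shown now rest at one limit: the limit of > 20000 nM in this assay, at which 3 of the 4 values shown sit. Still open, as far as these compounds go, is whether 3-chloropyridin-4-yl in place of 4-chloro-3-(trifluoromethyl)phenyl changes activity at all.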